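Permeability notes: benzyl-side change from compound 3 to compound 4

The source may hold more compounds than are shown below. What is called first, only, known or untested is meant among the compounds shown, and "the series" means these compounds.

Three compounds of the series have numbers in an ADME assay for permeability, using PAMPA, with a stated time of 30 min, at pH 7.4; a lower number here means that the compound crosses the layer more slowly, a higher number that the compound crosses the layer faster. Compound 1 `COc1cccc(CNCCCNc2ccnc3cc(Cc4cc(C)cc(C)c4)ccc23)c1O` gives 23 10^-6 cm/s, and compound 2 `COc1cccc(CNCCCNc2ccnc3cc(CCC(C)C)ccc23)c1O` gives 23 10^-6 cm/s; the step of no change at the digits printed from compound 1 to compound 2 (within the scatter). Compound 3 `c1ccc(-c2ccc3c(NCCCNCc4ccco4)ccnc3c2)cc1` gives 237 10^-6 cm/s, the highest of the three values, and its distance to compound 1 and to compound 2 lies beyond the scatter in both cases.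

Compound 4 `COc1cccc(CNCCCNc2ccnc3cc(-c4ccccc4)ccc23)c1O` differs from compound 3 in one place: 2-hydroxy-3-methoxyphenyl in place of furan-2-yl on a saturated chain carbon bound to an amine nitrogen. Among the compounds with values here, no measured step covers this change; the only measured step, no change at the digits printed from compound 1 to compound 2 (within the scatter), sits at the other end of the molecule. What bears on the change is that the entering 2-hydroxy-3-methoxybenzyl is the group carried by compound 1, at 23 10^-6 cm/s, and by compound 2, at 23 10^-6 cm/s, both far below compound 3. The step is therefore expected to be a decrease beyond the scatter, a 5.9-fold lower number from compound 3 to compound 4 (0.77 log units; beyond the scatter). Compound 4 is expected to give about 40 10^-6 cm/s, within a range from 15 10^-6 cm/s to 110 10^-6 cm/s.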

Compound 4, apparent permeability: 237 10^-6 cm/s
Estimate against measurement, compound 4: 5.9-fold (0.77 log units) below; measured number above the stated range.
By their numbers in this assay, from the lowest: compounds 1 and 2 (each within the scatter of the next); then compounds 3 and 4 (each within the scatter of the next).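

In this assay, replacing furan-2-yl with 2-hydroxy-3-methoxyphenyl on a saturated chain carbon bound to an amine nitrogen gives no change at the digits printed from compound 3 to compound 4 (within the scatter), so the group shared with the two low compounds does not by itself bring a low number when phenyl sits on the aromatic carbon. With that group held constant, the group on the aromatic carbon separates the compounds: phenyl in place of isopentyl gives a 10-fold higher number from compound 2 to compound 4 (1.01 log units; beyond the scatter), and phenyl in place of 3,5-dimethylbenzyl gives a 10-fold higher number from compound 1 to compound 4 (1.01 log units; beyond the scatter). No supporting measurement here accounts for either result.

As far as these compounds go, it remains open whether isopentyl or 3,5-dimethylbenzyl on the aromatic carbon would also give a low number with furan-2-yl on the chain carbon. Also open, from the compounds shown here alone, is how a pyridyl group or a carboxylic acid in place of phenyl would read in this assay.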